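A few compounds are considered here, and "the series" means these few. Any claim that something is new, unique, unknown or untested is made for them only; others in the source may bear on it.

Series notes, permeability.

Measured so far in an ADME assay on MDCK cells (Canis lupus familiaris) for permeability, in the apical to basolateral direction; a lower number here means that the compound crosses the layer more slowly, a higher number that the compound crosses the layer faster:
- compound 1 `CC(C)[C@@H](C[C@H]1SC(=O)NC1=O)c1ccc(-c2ccc3cccc(F)c3c2)[nH]c1=O` gives 25.5 10^-6 cm/s
- compound 2 `CC(C)C(c1ccc(-c2ccc3cccc(F)c3c2)[nH]c1=O)C1SC(=O)NC1=O` gives 26.3 10^-6 cm/s
- compound 3 `CC(C)/C(=C1\NC(=O)OC1=O)c1ccc(-c2ccc3cccc(F)c3c2)[nH]c1=O` is recorded as "not determined" (no result reported) in this assay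

Compound 2 carries the higher of the two numbers, but compound 1 lies within the usual scatter of it, so the two are read as the same result; compound 3 adds nothing, as no number was reported. Compound 4 `CC(C)C(/C=C1\SC(=O)NC1=O)c1ccc(-c2ccc3cccc(F)c3c2)[nH]c1=O` is the next entry for this assay. Compared with compound 2 it carries a group of 8 heavy atoms (4 carbon, 1 nitrogen, 2 oxygen, 1 sulfur; one five-membered non-aromatic ring with 2 hetero atoms) in place of a group of 7 heavy atoms (3 carbon, 1 nitrogen, 2 oxygen, 1 sulfur; one five-membered non-aromatic ring with 2 hetero atoms), on a saturated chain carbon bound to an aromatic carbon and a saturated chain carbon. For the measured compounds named here, no pair of measured compounds differs in a single place, so there is no step to lean on, and the one comparison to hand, compound 1 against compound 2, shows nothing beyond the scatter. On that footing the step from compound 2 to compound 4 is expected to be a 1.0-fold higher number from compound 2 to compound 4 (0.01 log units; within the scatter), that is, no change beyond the scatter in either direction. Compound 4 is therefore expected to give about 27 10^-6 cm/s in this assay, with a range from 14 10^-6 cm/s to 50 10^-6 cm/s.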

Compound 4, apparent permeability: 15.4 10^-6 cm/s
The estimate for compound 4 lay 1.8-fold (0.24 log units) above the measured number; low and high end bracket the measured number.
By their numbers in this assay, from the lowest: compounds 4, 1 and 2 (each within the scatter of the next).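

In this assay, the group of compound 4 in place of 2,4-dioxo-1,3-thiazolidin-5-yl, on a saturated chain carbon bound to an aromatic carbon and a saturated chain carbon, gives a 1.7-fold lower number from compound 2 to compound 4 (0.23 log units; within the scatter). For the compounds shown here, this is the first step that changes a single place, and it shows that this exchange at this position does not move the permeability reading beyond the scatter. No measurement shown bears on what lies behind this result.

A single step at one position leaves open how far this reading holds for other groups there, such as an amine, a carboxylic acid or a longer chain. Compound 3 has no number, so its ring system at this position remains unplaced in this series.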